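The source may hold more compounds than are shown below. What is called first, only, known or untested is meant among the compounds shown, and "the series" means these compounds.

Working notes on the series. In an ADME assay on L132 cells (Homo sapiens) for cytotoxicity, read by MTT assay, with a stated time of 72 h (a higher number here means a weaker inhibitor, a lower number a stronger inhibitor), compound 1 (`COc1cc(C2=C(c3ccc(OCC(=O)O)cc3)C(O)CC2=O)cc(OC)c1OC`) stands as "not determined" (no result reported) and offers no number for comparison. Among the compounds with values here, compound 2 (`COc1ccc(C2=C(c3cc(OC)c(OC)c(OC)c3)C(=O)CC2O)cc1`) gives 10 ug/mL in this assay and is so far the only reading, which leaves it with no rank against any other compound. Compound 3 (`CCOC(=O)COc1ccc(C2=C(c3cc(OC)c(OC)c(OC)c3)C(=O)CC2O)cc1`) differs from compound 2 in one place (ethoxycarbonyl in place of hydrogen on a saturated chain carbon bound to an oxygen on an aromatic ring), with ethoxycarbonyl in place of hydrogen on a saturated chain carbon bound to an oxygen on an aromatic ring. The same difference reads as methoxy to (ethoxycarbonyl)methoxy. Within the data shown here, no pair of measured compounds shows what a change of this kind does, so the series offers no step to carry over and no direction to favour. The expectation is therefore a step no larger than the usual scatter of repeated measurements, and the estimated step of no change at the digits printed from compound 2 to compound 3 (within the scatter) is to be read in that sense. In this assay compound 3 is estimated at 10 ug/mL within an expected range of 4 ug/mL to 30 ug/mL.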

Compound 3, half-maximal inhibitory concentration: > 100 ug/mL
Compound 3 was reported as a limit (the forecaster's own chance of this, stated with the estimate: 10%); middle value at least 10-fold (1.00 log units) from the limit.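

In this assay, this position now has its first reading: ethoxycarbonyl in place of hydrogen on a saturated chain carbon bound to an oxygen on an aromatic ring gives an at least 10-fold higher number from compound 2 to compound 3 (1.00 log units; beyond the scatter). For compound 3, the reading of > 100 ug/mL is a limit of the assay and not a number: the limit of > 100 ug/mL in this assay, at which 1 of the 3 values shown sits. The position is therefore not silent in this assay, since the change from methoxy to (ethoxycarbonyl)methoxy moves the series towards a weaker inhibitor, though this rests on a single pair and the full size of the step cannot be read.

The compounds shown leave open which part of the entering group goes with this step, the carbonyl or the ethyl end, and whether any smaller group on the same carbon would already give it. From the compounds shown here alone, it also remains open whether an amine or an amide in place of the ethoxycarbonyl, or a longer chain carrying the same ester, would give a reading in this assay that stays a number or one that again reaches the limit.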